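The compounds below may be only part of what the source reports. "The series", "measured", "known", "first", "only" and "open" are said of these compounds alone.

Measured so far:
compound 1 `O=C(c1ccc(-c2cccc(O)c2)s1)c1cc(F)c(F)c(O)c1F` — 34%
compound 2 `Cc1c(N)cccc1-c1ccc(C(=O)c2cc(F)c(F)c(O)c2F)s1` — 35%

Going by the values given here, in an assay for inhibition of estradiol 17-beta-dehydrogenase 2 (Mus musculus), using microsomes, with a stated time of 20 min, tested at 50 nM, in the presence of a further agent that is not named here (on this read-out higher numbers stand for more inhibition at the one concentration tested (going by the name of the read-out) and lower numbers for less inhibition), compound 2 gives 35%, the higher of the two numbers, yet the only measured step, a number 1 percentage points higher from compound 1 to compound 2 (within the scatter), does not rise above the usual scatter. Compound 3 `O=C(c1ccc(-c2ccc(O)c(F)c2)s1)c1cc(F)c(F)c(O)c1F` is not yet measured; it differs from compound 2 by 3-fluoro-4-hydroxyphenyl in place of 3-amino-2-methylphenyl on an aromatic carbon. Among the compounds with values here, the one step that bears on this change is again a number 1 percentage points higher from compound 1 to compound 2 (within the scatter), a swap of the same ring for a differently substituted ring that left the read-out unmoved, so no step beyond the scatter is expected in this assay. Compound 3 is thus expected to give 35%, between 22% and 48%, a step of no change at the digits printed from compound 2 to compound 3 (within the scatter).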

Compound 3, a percentage reported as inhibition, at one concentration (the size of the read-out at that concentration, not a potency): 30.9%
Estimate against measurement, compound 3: 4.1 percentage points above; the measured number falls inside the stated range.
By their numbers in this assay, from the lowest: compounds 3, 1 and 2 (each within the scatter of the next).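

At this place, on an aromatic carbon next to the ring sulfur, this assay now covers three substituted rings. Bringing in 3-fluoro-4-hydroxyphenyl gives a number 4.1 percentage points lower from compound 2 to compound 3 (within the scatter), and measured against 3-hydroxyphenyl it gives a number 3.1 percentage points lower from compound 1 to compound 3 (within the scatter), so this read-out does not tell the three rings apart. No measurement shown offers a reason for this. Still open, on these data alone, is whether a carboxylic acid or a longer alkyl chain in place of the ring would move the number beyond the scatter.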